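Methoxy to hydroxy on compound 1

This account rests on a few compounds, and the source may have more. Where it says the series, first, only, none or still open, it means among the compounds named here.

- compound 1 (`COc1ccc(C2=C(c3ccc(SC)cc3)CC3CCCN3C2=O)cc1O`) gives 20000 nM in a functional assay on SW-620 cells (Homo sapiens) for cytotoxicity; a lower number here means a stronger inhibitor of growth, a higher number a weaker inhibitor of growth
- compound 2 (`CSc1ccc(C2=C(c3ccc(F)c(C)c3)C(=O)N3CCCC3C2)cc1`) gives 600 nM in this assay

Among the measured compounds shown here, compound 1 holds the higher of the two numbers so far. Compound 3 (`CSc1ccc(C2=C(c3ccc(O)c(O)c3)C(=O)N3CCCC3C2)cc1`) has not yet been measured. It differs from compound 1 by hydrogen in place of methyl on an oxygen on an aromatic ring, which turns 3-hydroxy-4-methoxyphenyl into 3,4-dihydroxyphenyl. For the measured compounds named here, one measured step bears on this group: a 33-fold lower number from compound 1 to compound 2 (1.52 log units; beyond the scatter) replaces all of it with 4-fluoro-3-methylphenyl. Going by the values given here, that large step shows the group matters, but no measured step isolates the loss of a methyl. A smaller step is therefore expected, probably towards a lower number, and a change within the scatter remains possible. The estimated change is a 2.9-fold lower number from compound 1 to compound 3 (0.46 log units; beyond the scatter) in this series. Compound 3 is expected at 7000 nM in this assay with 1500 nM to 30000 nM as the estimated range.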

Compound 3, concentration for 50% growth inhibition: 50000 nM
Compound 3: middle estimate off by 7.1-fold (0.85 log units), on the low side; measured number above the stated range.
By their numbers in this assay, from the lowest: compound 2; then compound 1; then compound 3.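

Hydrogen in place of methyl on an oxygen on an aromatic ring is the first change here confined to a single group, and in this assay it gives a 2.5-fold higher number from compound 1 to compound 3 (0.40 log units; beyond the scatter) as a modest move towards weaker growth inhibition. Of the three aryl groups compared at this position, 3,4-dihydroxyphenyl therefore gives the weakest growth inhibition, and an 83-fold higher number from compound 2 to compound 3 (1.92 log units; beyond the scatter) makes the spread at this position wider than the earlier pair showed. No evidence on hand accounts for either step.

As far as these compounds go, it remains open whether the same methoxy to hydroxy change would run in the same direction on other aryl groups of this series. Also open, from the compounds shown here alone, is how an amine or a carboxylic acid in place of the hydroxy on this ring would read in this assay.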